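A few compounds are considered here, and "the series" means these few. Any claim that something is new, unique, unknown or untested is made for them only; others in the source may bear on it.

Compound 1, with the structure `CCCCC(=O)NC(=S)Nc1nc2cc([N+](=O)[O-])ccc2s1`, is one of three measured members of this small thiourea series. In a functional assay on MCF7 cells (Homo sapiens) for cytotoxicity, read by MTT assay, with a stated time of 24 h (on this read-out higher numbers stand for weaker inhibition and lower numbers for stronger inhibition), compound 1 gives only a limit, > 100000 nM, and this is the limit noted as the limit of > 100000 nM in this assay, at which 1 of the 3 values shown sits. Compound 2, `CCCCC(=O)NC(=S)Nc1nc2ccccc2s1`, gives 36600 nM in this assay. The two differ in one place, (hydrogen in place of nitro on an aromatic carbon), and that change brought an at least 2.7-fold lower number from compound 1 to compound 2 (0.43 log units; beyond the scatter). Compound 3, `O=C(NC(=S)Nc1nc2cc(Br)ccc2s1)c1ccc([N+](=O)[O-])cc1`, gives 32400 nM in this assay, a value that sits within the scatter of compound 2, so no order between them can be read. Compound 3 and compound 1 share the thiourea link but their cores differ in more than one place, and the difference between the two cores is not broken down here.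

Compound 4, `O=C(NC(=S)Nc1nc2cc(Br)ccc2s1)c1ccccc1`, has not yet been measured. It differs from compound 3 by hydrogen in place of nitro on an aromatic carbon. Among the compounds with values here, this is the same kind of change as the one from compound 1 to compound 2, yet not the same change: there the nitro left a six-membered aromatic ring of carbon only that is part of a fused or bridged system of two rings, meta to a fused ring and para to a fused ring, whereas here it leaves a six-membered aromatic ring of carbon only, para to a large group. Because the earlier step was an at least 2.7-fold lower number from compound 1 to compound 2 (0.43 log units; beyond the scatter), compound 4 is expected to show a step of about a 1.6-fold lower number from compound 3 to compound 4 (0.21 log units; within the scatter) in this assay, with the wider uncertainty that the different place brings. Compound 4 is therefore estimated at 20000 nM, with a range from 7000 nM to 60000 nM.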

Compound 4, half-maximal inhibitory concentration: 32100 nM
Compound 4: the middle estimate sits 1.6-fold (0.21 log units) below what was measured, within the range that was stated.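

In this assay, hydrogen in place of nitro on the core of compound 3 brought a 1.0-fold lower number from compound 3 to compound 4 (0.00 log units; within the scatter), so the step seen on the core of compound 1 did not carry over in size to this second core: the same change on two cores in this assay, an at least 2.7-fold lower number (0.43 log units; beyond the scatter) from compound 1 to compound 2 and a 1.0-fold lower number (0.00 log units; within the scatter) from compound 3 to compound 4, at least 2.7-fold (0.43 log units) apart, beyond the scatter of two such steps

Compound 1 carries a limit of the assay and not a number, so the earlier step has a known lower bound but no known size: the limit of > 100000 nM in this assay, at which 1 of the 4 values shown sits.

The result shows that in this series the same exchange need not give the same step on two cores, but it does not show why, since the two pairs differ at once in the ring that carries the nitro and in the rest of the molecule, and two pairs support no general rule for any further core.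

The compounds shown leave open how an amine or a carboxylic acid in the place of the nitro, on the ring of compound 4, would read in this assay. Within the data shown here, they also leave open whether a longer chain in place of the one on compound 2 would shift the number beyond the scatter.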